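The compounds below may be only part of what the source reports. "The series", "measured", "known", "first", "only" and "open" are said of these compounds alone.

Values in a functional assay on cells (Panel NCI-60 (60 carcinoma cell lines), Homo sapiens) for inhibition, read by colorimetric assay, with a stated time of 3 days (a lower number here means a stronger inhibitor of growth, a higher number a weaker inhibitor of growth), for the compounds measured so far:

Compound 1 `COc1ccc2sc(NC(=O)CCCCCCNC(=O)C(O)(O)C(F)(F)F)nc2c1` gives 12300 nM
Compound 2 `O=C(CCCCCCNC(=O)C(O)(O)C(F)(F)F)Nc1ccc(Br)cc1` gives 20900 nM
Compound 3 `O=C(CCCCCCNC(=O)C(O)(O)C(F)(F)F)Nc1ccc(-c2ccccc2)cc1` gives 15100 nM

Compound 2, at 20900 nM, stands within the usual scatter of both other compounds, so these three numbers cannot be ranked. Compound 4 `O=C(CCCCCCNC(=O)C(O)(O)C(F)(F)F)Nc1nc2ccccc2s1` has not yet been measured. It departs from compound 2 on an amide-type nitrogen, where 1,3-benzothiazol-2-yl takes the place of 4-bromophenyl (1,3-benzothiazol-2-yl in place of 4-bromophenyl on an amide-type nitrogen), while the rest of the molecule stays the same.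

Within the data shown here, only one measured step starts from compound 2: a 1.4-fold lower number from compound 2 to compound 3 (0.14 log units; within the scatter), seen when phenyl replaces bromo on an aromatic carbon. That is a different change, so it offers only a loose guide, and it is small. Compound 1 and compound 2 also lie within the scatter of each other. With compound 3 at 15100 nM and compound 1 at 12300 nM, no step beyond the scatter is expected in this assay, and the direction remains uncertain. The estimated step is a 1.4-fold lower number from compound 2 to compound 4 (0.14 log units; within the scatter). For compound 4 the expected value is 15000 nM, with an estimated range of 8000 nM to 28000 nM.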

Compound 4, concentration for total growth inhibition: 21400 nM
The estimate for compound 4 lay 1.4-fold (0.15 log units) below the measured number; the range from low to high includes it.
By their numbers in this assay, from the lowest: compounds 1, 3, 2 and 4 (each within the scatter of the next).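

In this assay, 1,3-benzothiazol-2-yl on the amide-type nitrogen gives a 1.0-fold higher number from compound 2 to compound 4 (0.01 log units; within the scatter) and so cannot be told apart from 4-bromophenyl there, even though the entering group brings a five-membered aromatic ring with hetero atoms and hydrogen-bond acceptors that the leaving group lacks. Among these compounds, the new compound also gives the first reading of a substituent on the benzothiazole group: hydrogen in place of methoxy on an aromatic carbon gives a 1.7-fold higher number from compound 1 to compound 4 (0.24 log units; within the scatter) and is likewise within the scatter, so the two compounds cannot be ranked. No supporting evidence is available to explain either result and these two steps describe only what the numbers show for these compounds.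

The compounds shown leave open whether any group on this amide-type nitrogen can produce a step beyond the scatter, for instance a pyridine ring, or a carboxylic acid or an amine on the aromatic ring. They also leave open what a shorter or longer chain between the two amide groups would do, since all four compounds share the same chain.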